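Methyl ester in place of acid across two cores

The compounds below may be only part of what the source reports. "The series", "measured", "known", "first", "only" and "open" are said of these compounds alone.

Compound 1 `O=C(O)c1ccc(-c2cnc(C(=O)CCc3ccc(-c4ccccc4)cc3)o2)cn1` gives 44 nM in an assay for inhibition of Fatty-acid amide hydrolase 1 (Rattus norvegicus); a higher number here means a weaker inhibitor, a lower number a stronger inhibitor. Compound 3 `COC(=O)c1ccc(-c2cnc(C(=O)CCc3ccc(-c4ccccc4)cc3)o2)cn1` carries the change (methyl in place of hydrogen on an oxygen next to a carbonyl group), and in this assay compound 3 gives 0.6 nM; the step is a 73-fold lower number from compound 1 to compound 3 (1.87 log units; beyond the scatter). Compound 2 `O=C(O)c1cccc(-c2cnc(C(O)CCc3ccc(-c4ccccc4)cc3)o2)n1` gives 1100 nM in this assay, the highest number of the three measured; the difference between the core of compound 2 and the core of compound 1 is not broken down here. Compound 4 `COC(=O)c1cccc(-c2cnc(C(O)CCc3ccc(-c4ccccc4)cc3)o2)n1` is not yet measured; from compound 2 it differs by methyl in place of hydrogen on an oxygen next to a carbonyl group. The place of the two changes reads the same, so they are taken as the same change, although read one bond further out the group on compound 2 is 6-carboxypyridin-2-yl where compound 1 has 6-carboxypyridin-3-yl. Within the data shown here, the only measured instance of this change is a 73-fold lower number from compound 1 to compound 3 (1.87 log units; beyond the scatter), and the expectation for compound 4 is a step of a 37-fold lower number from compound 2 to compound 4 (1.56 log units; beyond the scatter) in this assay, resting on that one step, with wide bounds as the cores are not compared in measured steps. Compound 4 is estimated at 30 nM in this assay, between 5 nM and 200 nM.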

Compound 4, inhibition constant: 9000 nM
The estimate for compound 4 lay 300-fold (2.48 log units) below the measured number; the whole stated range lies below it.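

Carboxy to methoxycarbonyl does not carry over between these two cores in this assay: the new step is an 8.2-fold higher number from compound 2 to compound 4 (0.91 log units; beyond the scatter), opposite in direction to the earlier step: the same change on two cores in this assay, a 73-fold lower number (1.87 log units; beyond the scatter) from compound 1 to compound 3 and an 8.2-fold higher number (0.91 log units; beyond the scatter) from compound 2 to compound 4, 600-fold (2.78 log units) apart, beyond the scatter of two such steps

A step measured on the core of compound 1 therefore gives neither the size nor the direction of the step on the core of compound 2, at least for this one pair of cores. It does not show which feature of the cores sets the outcome, as compound 2 has a 6-carboxypyridin-2-yl group and a hydroxy group on the chain where compound 1 has a 6-carboxypyridin-3-yl group and a carbonyl.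

The compounds shown leave open which of these two differences goes with the reversal, a question that acid and methyl ester pairs carrying only one of them would address. Also open, from the compounds shown here alone, is whether an ethyl ester or a primary amide in place of the methoxycarbonyl group would follow the step on either core.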